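Ester tail changes and microsomal half-life in the series

A few compounds are considered here, and "the series" means these few. Any claim that something is new, unique, unknown or untested is made for them only; others in the source may bear on it.

Compound 1 `CCOC(=O)/C=C/c1ccc(NC(=O)C2(NC(=O)c3ccc4c(C5CCCC5)c(-c5ncc(Cl)cn5)n(C)c4c3)CCC2)cc1OCC` is the reference point. In an ADME assay (liver) for pharmacokinetics, with Liver microsome (Homo sapiens) as the target, using microsomes (on this read-out higher numbers stand for a longer-lived compound and lower numbers for a shorter-lived compound), compound 1 gives > 5 h, a limit of the assay rather than a number (the limit of > 5 h in this assay, at which 1 of the 3 values shown sits). Compound 2 `CCCCCCOC(=O)/C=C/c1ccc(NC(=O)C2(NC(=O)c3ccc4c(C5CCCC5)c(-c5ncc(Cl)cn5)n(C)c4c3)CCC2)cc1OCC` gives 17.9 h in this assay, and compound 3 `CCOc1cc(NC(=O)C2(NC(=O)c3ccc4c(C5CCCC5)c(-c5ncc(Cl)cn5)n(C)c4c3)CCC2)ccc1/C=C/C(=O)OCC(=O)N1CCCC1` gives 1.65 h. Between them stand a step that the limit leaves unreadable from compound 1 to compound 2, an at least 3.0-fold lower number from compound 1 to compound 3 (0.48 log units; beyond the scatter) and an 11-fold lower number from compound 2 to compound 3 (1.04 log units; beyond the scatter). Compound 4 `CCOc1cc(NC(=O)C2(NC(=O)c3ccc4c(C5CCCC5)c(-c5ncc(Cl)cn5)n(C)c4c3)CCC2)ccc1/C=C/C(=O)OCC(=O)N1CCOCC1` differs from compound 1 as follows: (morpholin-4-yl)carbonyl in place of methyl on a saturated chain carbon bound to an oxygen next to a carbonyl group. The nearest measured comparison is an at least 3.0-fold lower number from compound 1 to compound 3 (0.48 log units; beyond the scatter), a change of the same kind at the same place; the change of compound 4 is expected to behave alike, so a step of an at least 3.1-fold lower number from compound 1 to compound 4 (0.49 log units; beyond the scatter) is expected. Compound 4 is therefore estimated at 1.6 h, within a range from 0.6 h to 4.5 h.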

Compound 4, half-life: 0.667 h
The estimate for compound 4 lay 2.4-fold (0.38 log units) above the measured number; the measured number falls inside the stated range.
By their numbers in this assay, from the lowest: compound 4; then compound 3; then compound 2.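

In this assay, the amide ring alone now moves the number: morpholin-4-yl in place of pyrrolidin-1-yl on a carbonyl carbon gives a 2.5-fold lower number from compound 3 to compound 4 (0.39 log units; beyond the scatter). The (morpholin-4-yl)carbonyl tail also gives a 27-fold lower number from compound 2 to compound 4 (1.43 log units; beyond the scatter) and an at least 7.4-fold lower number from compound 1 to compound 4 (0.87 log units; beyond the scatter), placing compound 4 lowest of the compounds shown. Compound 1 stands at a limit of the assay: the limit of > 5 h in this assay, at which 1 of the 4 values shown sits.

Going by these compounds, whether the drop holds for other amides remains open, for example a piperazine amide or an open-chain dimethylamide. On these data alone, how a free carboxylic acid at this position would read also remains open.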